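A few compounds are considered here, and "the series" means these few. Any claim that something is new, unique, unknown or untested is made for them only; others in the source may bear on it.

Measured compounds: compound 1 `COc1ccc(C(O)(c2cc3cc([N+](=O)[O-])cc(-c4ccccc4)c3o2)c2cncn2C)cc1` at 4970 nM; compound 2 `COc1cccc(-c2cc(CN(C)C)cc3cc(C(O)(c4ccc(C#N)cc4)c4cncn4C)oc23)c1` at 142 nM; compound 3 `COc1cccc(-c2cc(C=O)cc3cc(C(O)(c4ccc(C#N)cc4)c4cncn4C)oc23)c1` at 15.2 nM, all in a functional assay on QG-56 cells (Homo sapiens) for antiproliferative activity; on this read-out lower numbers stand for stronger inhibition and higher numbers for weaker inhibition.

Compound 1 stands highest of the three, weakest on this read-out; compound 2 lies nearer to it and compound 3 furthest. Compound 4 `Cn1cncc1C(O)(c1ccc(C#N)cc1)c1cc2cc([N+](=O)[O-])cc(-c3ccccc3)c2o1` differs from compound 1 by cyano in place of methoxy on an aromatic carbon, the 4-methoxyphenyl becoming a 4-cyanophenyl. Within the data shown here, no measured pair carries this same change: the one step, a 9.3-fold lower number from compound 2 to compound 3 (0.97 log units; beyond the scatter), concerns a different position, and compounds 2 and 3 differ from compound 1 in more than one place. The direction is therefore taken only loosely from compounds 2 and 3, which both bear the cyano and both sit far lower. A modest downward step a 3.3-fold lower number from compound 1 to compound 4 (0.52 log units; beyond the scatter) is expected, with wide uncertainty. Compound 4 is estimated at 1500 nM, between 400 nM and 6000 nM.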

Compound 4, half-maximal inhibitory concentration: 1480 nM
For compound 4 the middle estimate is 1.0-fold (0.01 log units) above the measured one; measured number inside the range.
By their numbers in this assay, from the lowest: compound 3; then compound 2; then compound 4; then compound 1.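

In this assay, cyano in place of methoxy on an aromatic carbon, para to a large group, gives a 3.4-fold lower number from compound 1 to compound 4 (0.53 log units; beyond the scatter). Among these compounds, this is the first direct reading of this position, as the earlier step concerned a different place on the core, and it shows that this single change alone moves the number beyond the scatter. Nothing shown here accounts for the size of this step.

On these data alone, it remains open whether an amine or a carboxylic acid on this aromatic carbon would give a lower or a higher number than cyano. Also open, as far as these compounds go, is whether the 4-methoxyphenyl to 4-cyanophenyl change gives a step of similar size on the core of compound 3.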